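Amide substituent changes in one cytotoxic series

The source may report more compounds than this note shows. Statements on the series, on what has been measured and on what is new or still open speak of the compounds shown alone.

Measured so far:
compound 1, `N#Cc1ccc(NC(=O)CN2C(=O)/C(=C/c3ccc(-c4ccc(Cl)cc4)o3)SC2=S)cc1`: 85000 nM
compound 2, `O=C(CN1C(=O)/C(=C/c2ccc(-c3ccc(Cl)cc3)o2)SC1=S)NCc1ccc(F)cc1`: 150000 nM
compound 3, `Cc1ccc(CNC(=O)CN2C(=O)/C(=C/c3ccc(-c4ccc(Cl)cc4)o3)SC2=S)cc1`: 45000 nM

In a functional assay on K562 cells (Homo sapiens) for cytotoxicity, read by MTT assay, with a stated time of 72 h (on this read-out lower numbers stand for stronger inhibition and higher numbers for weaker inhibition), compound 3 gives the lowest of the three numbers, yet only its gap to compound 2 is beyond the scatter: a 3.3-fold lower number from compound 2 to compound 3 (0.52 log units; beyond the scatter), whereas a 1.9-fold lower number from compound 1 to compound 3 (0.28 log units; within the scatter) is not.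

Compound 4, `CCCCCCNC(=O)CN1C(=O)/C(=C/c2ccc(-c3ccc(Cl)cc3)o2)SC1=S`, differs from compound 3 at the amide end: pentyl in place of 4-methylphenyl on a saturated chain carbon bound to an amide-type nitrogen.

All measured steps alter the same amide-type nitrogen substituent, and all are small: a 1.8-fold higher number from compound 1 to compound 2 (0.25 log units; within the scatter), a 1.9-fold lower number from compound 1 to compound 3 (0.28 log units; within the scatter), a 3.3-fold lower number from compound 2 to compound 3 (0.52 log units; beyond the scatter). Among the measured compounds shown here, none exchanges an aromatic group for a plain chain, so the pentyl change has no direct precedent, but the amide end has so far tolerated each variation with little movement. The step of a 1.3-fold higher number from compound 3 to compound 4 (0.12 log units; within the scatter) is therefore expected to stay within the scatter, with a slight drift toward weaker inhibition as the more likely direction.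

Compound 4 is estimated at 60000 nM in this assay, in the range 25000 nM to 150000 nM.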

Compound 4, half-maximal inhibitory concentration: 50000 nM
Estimate against measurement, compound 4: 1.2-fold (0.08 log units) above, and the stated range covers the measured number.
By their numbers in this assay, from the lowest: compounds 3, 4, 1 and 2 (each within the scatter of the next, the first and the last beyond it).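

In this assay, a plain chain on the amide-type nitrogen does as well as the aromatic groups of compound 1 and compound 3: a 1.1-fold higher number from compound 3 to compound 4 (0.05 log units; within the scatter) and a 1.7-fold lower number from compound 1 to compound 4 (0.23 log units; within the scatter) both stay within the scatter, so this position needs no aromatic ring to hold the number at this level. Among the compounds shown here, the only new step beyond the scatter is a 3.0-fold lower number from compound 2 to compound 4 (0.48 log units; beyond the scatter), and it is modest. Nothing available explains these steps.

From the compounds shown here alone, whether a longer chain, an amine or a carboxylic acid at this position would move the number remains open.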